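A Longer Ether Side Chain on Compound 3

The source may hold more compounds than are shown below. What is called first, only, known or untested is meant among the compounds shown, and "the series" means these compounds.

Measured values in a physicochemical assay for solubility, read by spectrophotometry, using the shake flask method, with a stated time of 2 days, at pH 6.5; a lower number here means a less soluble compound, a higher number a more soluble compound:
- compound 1 `O=C(O)COc1ccc2nc(-c3cn(-c4ccc(O)c(F)c4)nn3)ccc2c1`: 37 ug/mL
- compound 2 `Oc1ccc(-n2cc(-c3ccc4ccccc4n3)nn2)cc1`: 2.2 ug/mL
- compound 3 `O=C(O)CCCOc1ccc2nc(-c3cn(-c4ccc(O)c(F)c4)nn3)ccc2c1`: 19.2 ug/mL

Among these three numbers, compound 3 gives 19.2 ug/mL, which lies within the scatter of compound 1, while compound 2 sits lower, beyond the scatter. The next compound to be tested in this assay is compound 4 `O=C(O)COCCOc1ccc2nc(-c3cn(-c4ccc(O)c(F)c4)nn3)ccc2c1`, and it departs from compound 3 in one place: carboxymethoxy in place of carboxymethyl on a saturated chain carbon, two bonds along the chain from an oxygen on an aromatic ring. In words, this is carboxymethoxy in place of carboxymethyl on a saturated chain carbon, two bonds along the chain from an oxygen on an aromatic ring.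

For the measured compounds named here, only one measured step touches this side chain: a 1.9-fold lower number from compound 1 to compound 3 (0.28 log units; within the scatter). Going by the values given here, it lies within the scatter, but it is a different change, 2-carboxyethyl in place of carboxy, and no measured step introduces carboxymethoxy. Among the compounds with values here, compound 2 differs from the others in more than one place and supplies no step here. The evidence is therefore thin, and no shift beyond the scatter is expected in this assay. The expected step is a 1.3-fold higher number from compound 3 to compound 4 (0.11 log units; within the scatter), with no firm direction. For compound 4 the estimated value is 25 ug/mL, with an expected range of 10 ug/mL to 60 ug/mL.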

Compound 4, solubility: 867 ug/mL
For compound 4 the middle estimate is 35-fold (1.54 log units) below the measured one; measured number above the stated range.
By their numbers in this assay, from the lowest: compound 2; then compounds 3 and 1 (each within the scatter of the next); then compound 4.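

In this assay, for the compounds shown here, this side chain proved far more sensitive than the earlier compounds had suggested: carboxymethoxy in place of carboxymethyl, two bonds along the chain from an oxygen on an aromatic ring, gives a 45-fold higher number from compound 3 to compound 4 (1.65 log units; beyond the scatter), while the only earlier step on this chain, a 1.9-fold lower number from compound 1 to compound 3 (0.28 log units; within the scatter), stayed within the scatter. The comparison with the shorter chain runs the same way, with (carboxymethoxy)methyl in place of carboxy on a saturated chain carbon bound to an oxygen on an aromatic ring giving a 23-fold higher number from compound 1 to compound 4 (1.37 log units; beyond the scatter), and since compounds 1, 3 and 4 all end in the same carboxy group, that ending alone does not separate compound 4 from the other two. No measurement shown here accounts for the size of these steps.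

The compounds shown leave open whether the jump follows the added chain oxygen or the longer chain, and a 4-carboxybutoxy chain on the same core would bear directly on that question. They also leave open whether a similar jump would appear with an amine in place of the terminal carboxylic acid.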